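The source may report more compounds than this note shows. Statements on the series, on what has been measured and on what is new or still open speak of the compounds shown alone.

Values in a physicochemical assay for lipophilicity, using the shake flask method, measured as octanol-water partition, at pH 7.4 (on this read-out lower numbers stand for lower lipophilicity and higher numbers for higher lipophilicity), as measured so far:
- compound 1 `CC(C)Cn1cc(-c2ccnc3[nH]c(C4CCN(CC(=O)N(C)C)CC4)cc23)ccc1=O` gives 2
- compound 2 `CC(C)n1cc(-c2ccnc3[nH]c(C4CCN(CC(=O)N5CCCCC5)CC4)cc23)ccc1=O` gives 2.8

Compound 1 at 2 stands lowest of the two, and compound 2 at 2.8 lies higher by more than the usual scatter. These two compounds differ in more than one place, so their gap cannot be read as the size of any single change.

Compound 3 `CN(C)C(=O)CN1CCC(c2cc3c(-c4ccc(=O)n(CC5CCOCC5)c4)ccnc3[nH]2)CC1` has not yet been measured. It departs from compound 1 in one place, with the change oxan-4-yl in place of isopropyl on a saturated chain carbon bound to an aromatic nitrogen being oxan-4-yl in place of isopropyl on a saturated chain carbon bound to an aromatic nitrogen. Cut one bond further out, the same difference reads isobutyl to (oxan-4-yl)methyl. Among the measured compounds shown here, no measured pair shows this change, so the expectation rests on the structural change alone and remains uncertain. A downward move is expected, and the estimated step of a number 0.60 log units lower from compound 1 to compound 3 (beyond the scatter) would probably lie beyond the scatter. For compound 3 the estimated value is 1.4 with an expected range from 0.9 to 1.9 in this assay once it is measured.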

Compound 3, distribution coefficient: 1.4
For compound 3 middle estimate and measured number coincide at the digits printed; the range from low to high includes it.
By their numbers in this assay, from the lowest: compound 3; then compound 1; then compound 2.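

In this assay, oxan-4-yl in place of isopropyl on a saturated chain carbon bound to an aromatic nitrogen gives a number 0.60 log units lower from compound 1 to compound 3 (beyond the scatter). Among the compounds shown here, this is the first change that can be read on its own, since the gap between compound 1 and compound 2 spans more than one place, and it shows that this position alone can move the read-out beyond the scatter. The entering group has more heavy atoms than the one it replaces, along with a six-membered non-aromatic ring and a hydrogen-bond acceptor, yet the number falls, although nothing at hand accounts for the step and this single pair cannot divide it between the ring and its oxygen.

The compounds shown leave open whether cyclohexyl in the same place, which has the ring without the oxygen, would lower the number as well, and how a morpholine or a carboxylic acid there would compare. They also leave open whether the step keeps its size on a molecule that differs from compound 1 elsewhere.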